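A few compounds are considered here, and "the series" means these few. Any claim that something is new, unique, unknown or untested is made for them only; others in the source may bear on it.

Measured in a physicochemical assay for lipophilicity, read by HPLC, measured as octanol-water partition; on this read-out higher numbers stand for higher lipophilicity and lower numbers for lower lipophilicity:
- compound 1 `Nc1ccccc1C(=O)N/N=C/c1ccc2no[n+]([O-])c2c1`: 2
- compound 2 `N#Cc1c(-c2ccco2)[n+]([O-])c2ccc(C3OCCO3)cc2[n+]1[O-]`: 2
- compound 3 `NC(=O)c1c(COc2cccc(/C=N/NC(=O)c3ccncc3)c2)no[n+]1[O-]`: 1.3

Compound 1 stands level with compound 2, and together they hold the highest number of the three. Compound 3 lies lower, beyond the scatter. Compound 4 `Nc1cccc(C(=O)N/N=C/c2ccc3no[n+]([O-])c3c2)c1` has the same atoms as compound 1, joined differently: 3-aminophenyl in place of 2-aminophenyl on a carbonyl carbon, with 3-aminophenyl in place of 2-aminophenyl on a carbonyl carbon. Among the measured compounds shown here, no two measured compounds differ in one place, so the data offer no measured step to lean on. Starting from compound 1 at 2, a shift no larger than the scatter is expected in this assay, if anything slightly downward. The estimated change is a number 0.10 log units lower from compound 1 to compound 4 (within the scatter). Compound 4 is expected at 1.9, with an estimated range of 1.5 to 2.3.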

Compound 4, partition coefficient: 1.4
Compound 4: middle estimate off by 0.50 log units, on the high side, and the stated range ends above it.
By their numbers in this assay, from the lowest: compounds 3 and 4 (each within the scatter of the next); then compounds 1 and 2 (each within the scatter of the next).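

In this assay, among the compounds shown here, 3-aminophenyl in place of 2-aminophenyl on a carbonyl carbon gives a number 0.60 log units lower from compound 1 to compound 4 (beyond the scatter), the first step in this set that can be read at a single place. The two groups match in atoms and in their counts of donors and acceptors, yet the read-out at this place still changes with how the group is joined. Nothing at hand accounts for this step.

On these data alone, whether a plain phenyl or a cyclohexyl on that carbonyl carbon reads nearer compound 1 or compound 4 stays open. So does whether the same change gives a similar step on another core.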